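Swapping the amide substituent in a weak cell-growth inhibitor

The source may report more compounds than this note shows. Statements on the series, on what has been measured and on what is new or still open speak of the compounds shown alone.

Of the compounds shown here, two sharing the same core have been tested in a functional assay on HeLa cells (Homo sapiens) for inhibition, read by MTT assay, with a stated time of 24 h; a higher number here means a weaker inhibitor, a lower number a stronger inhibitor. Compound 1 `CCOC(=O)C1=Cc2ccccc2OC1(OCc1cn(-c2ccc(F)c([N+](=O)[O-])c2)nn1)C(F)(F)F` gives 15600 nM. Compound 2 `CCOC(=O)C1=Cc2ccccc2OC1(OCc1cn(CC(=O)NC2CCCCC2)nn1)C(F)(F)F` gives 11400 nM. The two numbers lie close together: the step of a 1.4-fold lower number from compound 1 to compound 2 (0.14 log units; within the scatter) stays within the scatter, so neither compound can be called the stronger inhibitor on this evidence, and compound 2 simply holds the lower of the two numbers.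

Compound 3 `CCOC(=O)C1=Cc2ccccc2OC1(OCc1cn(CC(=O)Nc2ccc(OC)cc2)nn1)C(F)(F)F` is the next candidate. It differs from compound 2 in one place: 4-methoxyphenyl in place of cyclohexyl on an amide-type nitrogen. Going by the values given here, no measured step touches this position. Among the compounds with values here, the only step on record changes the group on the aromatic nitrogen, on the other side of the molecule, and even that step lies within the scatter, so it carries no lesson for the amide end. With nothing to lean on, the expectation is that compound 3 behaves much like compound 2, and the step of a 1.0-fold lower number from compound 2 to compound 3 (0.02 log units; within the scatter) is expected to fall within the scatter. Compound 3 is therefore estimated at 11000 nM, within a range from 4000 nM to 30000 nM.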

Compound 3, half-maximal inhibitory concentration: 31900 nM
Compound 3: middle estimate off by 2.9-fold (0.46 log units), on the low side; measured number outside the range, above it.
By their numbers in this assay, from the lowest: compounds 2 and 1 (each within the scatter of the next); then compound 3.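

In this assay, going by these compounds alone, the amide-type nitrogen proves to be a position where a change can register: with 4-methoxyphenyl in place of cyclohexyl there is a 2.8-fold higher number from compound 2 to compound 3 (0.45 log units; beyond the scatter) and this is the first step to pass beyond the scatter, though only modestly. The same holds when the whole group on the aromatic nitrogen is compared, since ((4-methoxyphenyl)carbamoyl)methyl in place of 4-fluoro-3-nitrophenyl gives a 2.0-fold higher number from compound 1 to compound 3 (0.31 log units; beyond the scatter) whereas (cyclohexylcarbamoyl)methyl in that place stayed within the scatter, which leaves compound 3 as the weakest inhibitor of the three. No measurement on hand explains why the number rises.

This single change replaces a non-aromatic ring with an aromatic one and also brings in a methoxy group, so the compounds shown cannot say which of the two goes with the higher number. Plain phenyl on the amide-type nitrogen would separate these two changes, while a simple butyl chain or a ring carrying an amine would show how far the number can move at this position.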